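Para Substituent Swaps on an Arylsulfonamide Growth Inhibitor

A few compounds are considered here, and "the series" means these few. Any claim that something is new, unique, unknown or untested is made for them only; others in the source may bear on it.

Measured compounds:
compound 1, `COc1ccc(S(=O)(=O)Nc2ccc(C)c(O)c2)cc1`, 51000 nM
compound 2, `CC(=O)Nc1ccc(S(=O)(=O)Nc2ccc(C)c(O)c2)cc1`, 48000 nM
compound 3, `Cc1ccc(NS(=O)(=O)c2ccc(Br)cc2)cc1O`, 20000 nM

The three compounds share one core and differ only in the group para on the sulfonyl-bearing ring. In a functional assay on A549 cells (Homo sapiens) for inhibition (on this read-out lower numbers stand for stronger inhibition of growth and higher numbers for weaker inhibition of growth), compound 1 and compound 2 sit close together, as the step of a 1.1-fold lower number from compound 1 to compound 2 (0.03 log units; within the scatter) shows. Compound 3 stands lowest of the three: the steps of a 2.6-fold lower number from compound 1 to compound 3 (0.41 log units; beyond the scatter) and a 2.4-fold lower number from compound 2 to compound 3 (0.38 log units; beyond the scatter) both lie beyond the scatter, so compound 3 is the strongest inhibitor of growth among the measured set.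

Compound 4, `Cc1ccc(NS(=O)(=O)c2ccc(I)cc2)cc1O`, continues from compound 3 with a single change: iodo in place of bromo on an aromatic carbon. Among the compounds with values here, no measured step concerns an iodo group, so the two bromo steps, both modest, tell only that a halogen at that position was favoured over methoxy and acetamido; they give no direct guide to a bromo-to-iodo exchange. With nothing in the data pointing either way, compound 4 is expected to stay near compound 3 in this assay, the estimated step being a 1.3-fold lower number from compound 3 to compound 4 (0.10 log units; within the scatter), within the scatter. Compound 4 is therefore estimated at 16000 nM in this assay, with a likely range from 6000 nM to 40000 nM.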

Compound 4, concentration for 50% growth inhibition: 15000 nM
Estimate against measurement, compound 4: 1.1-fold (0.03 log units) above; the range from low to high includes it.
By their numbers in this assay, from the lowest: compounds 4 and 3 (each within the scatter of the next); then compounds 2 and 1 (each within the scatter of the next).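

In this assay, the exchange on this aromatic carbon, para to a large group, gives a 1.3-fold lower number from compound 3 to compound 4 (0.12 log units; within the scatter), so the data do not separate iodo from bromo here, even though iodine is the heavier atom of the two. The lower numbers seen with bromo therefore extend to a second halogen: replacing acetamido with iodo gives a 3.2-fold lower number from compound 2 to compound 4 (0.51 log units; beyond the scatter), and replacing methoxy with iodo gives a 3.4-fold lower number from compound 1 to compound 4 (0.53 log units; beyond the scatter), with both steps modest in size and none of the four compounds going against this grouping of the two halogens below the two other groups. No measurement on hand bears on why the two halogens give such similar numbers or why they differ from methoxy and acetamido.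

The compounds shown leave open how chloro, fluoro, an amine or a carboxylic acid on this same carbon would compare with the two halogens, and so whether the grouping extends beyond bromo and iodo. They also leave open how far the hydroxy and methyl groups of the shared core contribute to growth inhibition, since all four compounds carry both unchanged.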